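Dropping the Ethoxycarbonyl from a Thiol Amide

The source may hold more compounds than are shown below. What is called first, only, known or untested is meant among the compounds shown, and "the series" means these compounds.

Compound 1 `Cc1c(C)c2c(c(C)c1O)CCC(C)(C(=O)NCCS)O2`: 93%
Compound 2 `CCOC(=O)C(CS)NC(=O)/C=C/c1ccccc1`: 86%

Of the compounds shown here, two carrying a free thiol have been tested in a functional assay, with a stated time of 30 min, tested at 200 uM; on this read-out lower numbers stand for a weaker effect and higher numbers for a stronger effect at the one concentration tested. Compound 1 gives 93%, and compound 2 gives 86%. The number for compound 2 is the lowest of the two shown, but its gap to compound 1 lies within the scatter, so no real difference between them can be claimed.

Compound 3 `O=C(/C=C/c1ccccc1)NCCS` has not yet been measured. It differs from compound 2 in one place: hydrogen in place of ethoxycarbonyl on a saturated chain carbon bound to an amide-type nitrogen and a saturated chain carbon. Among the compounds with values here, no measured pair shows what this change does here, so only a small step is expected, slightly downward if anything, as a number 6 percentage points lower from compound 2 to compound 3 (within the scatter). Compound 3 is estimated at 80%, with a range from 60% to 95%.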

Compound 3, a percentage reported as activity, at one concentration (the size of the read-out at that concentration, not a potency): 86%
Compound 3: middle estimate off by 6 percentage points, on the low side, within the range that was stated.
By their numbers in this assay, from the lowest: compounds 2, 3 and 1 (each within the scatter of the next).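

In this assay, hydrogen in place of ethoxycarbonyl on this saturated chain carbon gives no change at the digits printed from compound 2 to compound 3 (within the scatter) and so shows that, at this one concentration, the read-out holds up without that group. The earlier compounds shown here differ in more than one place and could not show this. Nothing measured here offers an explanation for this result.

From the compounds shown here alone, whether a carboxylic acid, an amine or a longer chain on this same carbon would also leave the read-out unchanged remains open. A single concentration also cannot show whether compound 2 and compound 3 differ in potency.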